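The source may report more compounds than this note shows. Statements on the series, on what has been measured and on what is new or still open speak of the compounds shown alone.

Three amides built on one shared core have been run in a functional assay on HT-29 cells (Homo sapiens) for cytotoxicity, read by MTT assay, with a stated time of 72 h; on this read-out lower numbers stand for stronger inhibition and higher numbers for weaker inhibition. Compound 1 `COc1ccc(C(=O)c2cc(OC)c(OC)c(OC)c2)cc1NC(=O)/C=C/c1ccc(C(F)(F)F)cc1` gives 1600 nM. Compound 2 `COc1cc(C(=O)c2cc(OC)c(OC)c(OC)c2)cc(NC(=O)/C=C/c2cc(OC)c(OC)c(OC)c2)c1OC` gives 3100 nM. Compound 3 `COc1ccc(/C=C/C(=O)Nc2cc(C(=O)c3cc(OC)c(OC)c(OC)c3)cc(OC)c2OC)cc1OC` gives 2300 nM, the second highest of the three numbers; its gaps to compound 2 and to compound 1 both lie within the scatter, so no order among the three can be read from these values. For the measured compounds named here, the single step that links two measured compounds, a 1.3-fold lower number from compound 2 to compound 3 (0.13 log units; within the scatter), took a methoxy group off the aryl ring of the cinnamoyl part and left the read-out within the scatter.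

Compound 4 `COc1cccc(/C=C/C(=O)Nc2cc(C(=O)c3cc(OC)c(OC)c(OC)c3)cc(OC)c2OC)c1` carries the same kind of change on the same ring: hydrogen in place of methoxy on an aromatic carbon, so 2-(3,4-dimethoxyphenyl)ethenyl becomes 2-(3-methoxyphenyl)ethenyl. Going by the values given here, the only step that bears on it, a 1.3-fold lower number from compound 2 to compound 3 (0.13 log units; within the scatter), was of this kind and stayed within the scatter. For compound 4 the step of a 1.2-fold lower number from compound 3 to compound 4 (0.06 log units; within the scatter) is therefore expected to stay within the scatter, with no direction beyond it. Compound 4 is estimated at 2000 nM, with a range from 900 nM to 4500 nM.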

Compound 4, half-maximal inhibitory concentration: 8700 nM
Beside the measured number, compound 4's estimate is 4.4-fold (0.64 log units) below it, outside the stated range (above it).
By their numbers in this assay, from the lowest: compounds 1, 3 and 2 (each within the scatter of the next); then compound 4.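

In this assay, for the compounds shown here, the methoxy para to a large group on the cinnamoyl aryl ring is the first place where hydrogen in place of methoxy moves the read-out beyond the scatter, with a 3.8-fold higher number from compound 3 to compound 4 (0.58 log units; beyond the scatter) (modest), whereas the same kind of change in a 1.3-fold lower number from compound 2 to compound 3 (0.13 log units; within the scatter) stayed within it. The outcome of this change therefore depends on which methoxy leaves, and the larger change from 3,4,5-trimethoxyphenyl to 3-methoxyphenyl, a 2.8-fold higher number from compound 2 to compound 4 (0.45 log units; beyond the scatter) (modest), also ends beyond the scatter. No measurement available here accounts for this difference between the two places.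

As far as these compounds go, it remains open whether this place favours methoxy specifically or would accept other groups. A hydroxy group, an ethoxy group or an amine on the same aromatic carbon would test this.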